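Amino for Nitro on Two Hydrazone Cores

A few compounds are considered here, and "the series" means these few. Any claim that something is new, unique, unknown or untested is made for them only; others in the source may bear on it.

Compound 1 `O=C(NN=C(c1ccccn1)c1ccccn1)c1ccc([N+](=O)[O-])cc1` and compound 2 `Nc1ccc(C(=O)NN=C(c2ccccn2)c2ccccn2)cc1` share one core; compound 3 `C/C(=N\NC(=O)c1ccc([N+](=O)[O-])cc1)c1cnccn1` and compound 4 `C/C(=N\NC(=O)c1ccc(N)cc1)c1cnccn1` share another, and the difference between the two cores is not broken down here. In an ADME assay on cells (Homo sapiens) for antiproliferative activity, read by MTT assay (on this read-out lower numbers stand for stronger inhibition and higher numbers for weaker inhibition), compound 1 gives 260 nM, while compound 2 gives 7640 nM. The change between them, (amino in place of nitro on an aromatic carbon), made a step of a 29-fold higher number from compound 1 to compound 2 (1.47 log units; beyond the scatter). Compound 3 gives 1390 nM in this assay. Compound 4 carries the same change on its own core, (amino in place of nitro on an aromatic carbon), at a place described in the same words. Because the earlier step of a 29-fold higher number from compound 1 to compound 2 (1.47 log units; beyond the scatter) was large and beyond the scatter, a step of similar size is expected here, estimated as a 22-fold higher number from compound 3 to compound 4 (1.33 log units; beyond the scatter). Compound 4 is therefore expected to give about 30000 nM in this assay, within an estimated range from 8000 nM to 120000 nM. This expectation rests on a single earlier pair, compound 1 and compound 2.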

Compound 4, half-maximal inhibitory concentration in the Homo sapiens assay: 58800 nM
Estimate against measurement, compound 4: 2.0-fold (0.29 log units) below; the range from low to high includes it.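

In the Homo sapiens assay the amino-for-nitro change gives a 42-fold higher number from compound 3 to compound 4 (1.63 log units; beyond the scatter), so the large step seen on the core of compound 1 also appears on the core of compound 3, and the two steps agree: the same change on two cores in the Homo sapiens assay, a 29-fold higher number (1.47 log units; beyond the scatter) from compound 1 to compound 2 and a 42-fold higher number (1.63 log units; beyond the scatter) from compound 3 to compound 4, 1.4-fold (0.16 log units) apart, within the scatter of two such steps. On the core of compound 3, the same change also gives a number 0.80 log units lower from compound 3 to compound 4 (beyond the scatter) in a physicochemical assay for lipophilicity (a higher number here means a more lipophilic compound, a lower number a more polar compound), making compound 4 the more polar compound of that pair: the measured partition coefficient of compound 3, 2.1, and of compound 4, 1.3, a number 0.80 log units lower (beyond the scatter). In the physicochemical assay compound 3 gives 2.1, and compound 4 gives 1.3. These results show the change carrying across these two cores, but they do not establish that it would do so on any other core, nor do they explain why the number rises.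

The compounds shown leave open whether a different group in this place, such as a nitrile, a carboxylic acid or a methoxy group, would behave like nitro or like amino.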